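The compounds below may be only part of what the source reports. "The series", "measured", "known", "first", "only" and "open" are said of these compounds alone.

Measured so far in a physicochemical assay for lipophilicity; on this read-out higher numbers stand for higher lipophilicity and lower numbers for lower lipophilicity:
- compound 1, `Cc1cc(=O)[nH]c2cc(NC(=O)c3ccc(F)cc3)ccc12`, gives 1.61
- compound 2, `COc1ccc(C(=O)Nc2ccc3c(C)cc(=O)[nH]c3c2)cc1OC`, gives 1.46
- compound 3, `Cc1cc(=O)[nH]c2cc(NC(=O)c3cccc4ccccc34)ccc12`, gives 1.72

Among these three numbers compound 1 stands second highest. Its nearest neighbour is compound 3, whose value lies a little higher, and its furthest is compound 2, whose value lies a little lower; both gaps fall within the usual scatter of this assay, so no order among the three can be read from them.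

Compound 4, `Cc1ccccc1C(=O)Nc1ccc2c(C)cc(=O)[nH]c2c1`, has not yet been measured in this assay. It differs from compound 1 in one place: 2-methylphenyl in place of 4-fluorophenyl on a carbonyl carbon. Going by the values given here, no step between two measured compounds matches this change, so the expectation rests on the change itself. A small step upward is expected, one that may only just clear the scatter. On that basis compound 4 is estimated at 1.9, with a range from 1.5 to 2.3. The step this estimate means, from compound 1 to compound 4, is expected to be a number 0.29 log units higher from compound 1 to compound 4 (within the scatter).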

Compound 4, partition coefficient: 1.71
Beside the measured number, compound 4's estimate is 0.19 log units above it, within the range that was stated.
By their numbers in this assay, from the lowest: compounds 2, 1, 4 and 3 (each within the scatter of the next).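

Going by these compounds alone, on the carbonyl carbon whose other neighbour is the amide-type nitrogen, the exchange of 4-fluorophenyl for 2-methylphenyl gives the first step in this assay that can be read at this place, a number 0.10 log units higher from compound 1 to compound 4 (within the scatter), the earlier compounds having offered no such pair. With the shared core held constant, this exchange of one carbon-only aromatic ring for another, each with 7 heavy atoms, leaves the read-out within what repeated measurements would give. No evidence on hand bears on why the step has this size.

Because the methyl and the fluorine change together, the compounds shown cannot separate the two, and plain phenyl at this place would be needed to do so. On these data alone, whether an aminophenyl, a carboxylic acid on the ring or a longer alkyl chain on this carbonyl carbon would move the read-out beyond the scatter remains open.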